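The source may report more compounds than this note shows. Statements on the series, on what has been measured and on what is new or still open speak of the compounds shown alone.

Measured so far:
Compound 1, `Cc1ccc(-c2nc(CNc3ccc(C(=O)NO)cc3)n(-c3ccccc3)n2)cc1`, gives 224 nM in an assay on Sf9 cells for inhibition of protein deacetylase HDAC6 (Homo sapiens), read by fluorescence, with a stated time of 40 min; a higher number here means a weaker inhibitor, a lower number a stronger inhibitor.
Compound 2, `Cc1cccc(-n2nc(-c3ccccc3)nc2CNc2ccc(C(=O)NO)cc2)c1`, gives 388 nM in this assay.
Compound 3, `Cc1ccc(-c2nc(CNc3ccc(C(=O)NO)cc3)n(-c3ccccc3)n2)s1`, gives 30.6 nM in this assay.

Compound 3 holds the lowest number of the three. Its nearest neighbour is compound 1, reached by a 7.3-fold lower number from compound 1 to compound 3 (0.86 log units; beyond the scatter); compound 2 lies further off, and the two values of compound 2 and compound 3 differ by more than the scatter.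

Compound 4, `O=C(NO)c1ccc(NCc2nc(-c3ccccc3)nn2-c2ccccc2)cc1`, has not been measured. Its difference from compound 3: phenyl in place of 5-methylthiophen-2-yl on an aromatic carbon. Within the data shown here, only one measured step touches this position, a 7.3-fold lower number from compound 1 to compound 3 (0.86 log units; beyond the scatter), which went from a six-membered carbon ring with a methyl to the five-membered sulfur ring with a methyl and lowered the number well beyond the scatter. Among the measured compounds shown here, compound 4 moves back to a six-membered carbon ring, but without the methyl; no measured pair speaks to removing that methyl. The expectation is therefore a rise in this assay of roughly the size of the earlier step in reverse, an 8.2-fold higher number from compound 3 to compound 4 (0.91 log units; beyond the scatter), bringing compound 4 near compound 1, with extra uncertainty from the missing methyl.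

Estimate for compound 4 in this assay: 250 nM, range 100 nM to 650 nM.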

Compound 4, half-maximal inhibitory concentration: 112 nM
For compound 4 the middle estimate is 2.2-fold (0.35 log units) above the measured one, and the stated range covers the measured number.
By their numbers in this assay, from the lowest: compound 3; then compounds 4, 1 and 2 (each within the scatter of the next, the first and the last beyond it).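

In this assay, a 3.7-fold higher number from compound 3 to compound 4 (0.56 log units; beyond the scatter), so the 5-methylthiophen-2-yl group keeps its advantage over a phenyl group that carries no methyl, and the earlier gain over 4-methylphenyl did not rest on the methyl of that six-membered ring alone. The two methyl positions also read differently: on the aromatic carbon of the 4-methylphenyl group, hydrogen in its place gives a 2.0-fold lower number from compound 1 to compound 4 (0.30 log units; within the scatter), while on the other aromatic ring, hydrogen in place of the methyl gives a 3.5-fold lower number from compound 2 to compound 4 (0.54 log units; beyond the scatter), so only the second change reads as a real step. Nothing at hand accounts for these differences between the aromatic groups.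

From the compounds shown here alone, what the methyl contributes on the five-membered sulfur ring remains open, and the plain thiophen-2-yl group would settle that question by direct comparison with compound 3. Also open is how an amine, a methoxy group or a chlorine atom on these aromatic rings would read in this assay, since methyl is the only substituent on them in the compounds shown.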